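Swapping the benzyl substituent on a weakly cytotoxic triazole

The source may report more compounds than this note shows. Statements on the series, on what has been measured and on what is new or still open speak of the compounds shown alone.

Measured compounds:
- compound 1, `Cc1ccc(Cn2cc(COc3ccc4c(=O)ccoc4c3)nn2)cc1`: > 100000 nM
- compound 2, `O=c1ccoc2cc(OCc3cn(Cc4ccc([N+](=O)[O-])cc4)nn3)ccc12`: 71300 nM
- compound 3, `O=c1ccoc2cc(OCc3cn(Cc4ccc(F)cc4)nn3)ccc12`: > 100000 nM

Three compounds share one core and differ only in the substituent on the benzyl group attached to the triazole. In a functional assay on MDA-MB-231 cells (Homo sapiens) for cytotoxicity, read by MTT assay, with a stated time of 48 h (on this read-out higher numbers stand for weaker inhibition and lower numbers for stronger inhibition), compound 1 gives > 100000 nM, which is a limit of the assay rather than a number. Compound 2 gives 71300 nM in this assay. Compound 3 gives > 100000 nM in this assay, again a limit. Two of the three values sit at the limit of > 100000 nM in this assay, at which 2 of the 3 values shown sit, so compound 1 stands at the weak end of what this assay can read.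

Compound 4, `O=c1ccoc2cc(OCc3cn(Cc4cccc(Cl)c4)nn3)ccc12`, is not yet measured. It differs from compound 1 by 3-chlorophenyl in place of 4-methylphenyl on a saturated chain carbon bound to an aromatic nitrogen. Among the compounds with values here, no measured step makes this exact change, but two steps alter the same phenyl substituent: the step of an at least 1.4-fold lower number from compound 1 to compound 2 (0.14 log units; that floor lies within the scatter) and the step that the two limits leave unreadable from compound 1 to compound 3. Neither reveals a shift beyond the scatter, and the limits keep the picture vague. The step from compound 1 to compound 4 is therefore expected to be small or none, with a real chance that this assay again returns only a limit. For compound 4 the expected value is 100000 nM, within 40000 nM to 300000 nM, meaning an estimated step of a number no higher from compound 1 to compound 4 (the limit leaves the size open).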

Compound 4, half-maximal inhibitory concentration: > 100000 nM
Compound 4: no number, only a limit (the forecaster's own chance of this, stated with the estimate: 55%); the middle value lies on the limit itself.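

Changing both the group and its place on the ring, from 4-methylbenzyl to 3-chlorobenzyl, still gives no number in this assay: compound 4 gives > 100000 nM, which is a limit of the assay. The steps to compound 4 from compound 1 and from compound 3 run between two limits and cannot be read. The one step that can be read is an at least 1.4-fold higher number from compound 2 to compound 4 (0.14 log units; that floor lies within the scatter), so the chlorine-bearing compound is not shown to differ from the nitro-bearing one, and the series now gathers at a single ceiling: the limit of > 100000 nM in this assay, at which 3 of the 4 values shown sit.

Compound 2, at 71300 nM, remains the only compound here with a measured number, and the compounds shown cannot tell whether that reading marks a real difference from the others or merely sits close to the edge of what the assay can read. Also open, on these data alone, is whether any other group at this place would give a clearly stronger reading, such as an amine or a carboxylic acid on the ring, or a longer chain in place of the single carbon that links the ring to the triazole.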